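Series notes: methoxy-to-hydroxy step on the pyridine

This account rests on a few compounds, and the source may have more. Where it says the series, first, only, none or still open, it means among the compounds named here.

Measured so far in an assay on cells for inhibition of cytochrome P450 11B1, mitochondrial (Homo sapiens), with a stated time of 6 h; on this read-out higher numbers stand for weaker inhibition and lower numbers for stronger inhibition:
Compound 1, `Cn1nc(-c2ccccc2)cc1Cc1cncc(O)c1`: 17 nM
Compound 2, `COc1cncc(Cc2ccc(-c3ccccc3F)nc2)c1`: 0.8 nM
Compound 3, `Oc1cncc(Cc2cc(-c3ccccc3)no2)c1`: 120 nM

Compound 2 gives the lowest number of the three in this assay, and both gaps, to compound 1 and to compound 3, lie beyond the scatter of repeated measurements; among these three compounds it is the strongest inhibitor. Compound 1 and compound 3 carry the hydroxy group on the pyridine and sit well above it, with compound 3 the weakest of the three.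

Compound 4, `Oc1cncc(Cc2ccc(-c3ccccc3F)nc2)c1`, is not yet measured. It differs from compound 2 in one place: hydrogen in place of methyl on an oxygen on an aromatic ring. For the measured compounds named here, no step between measured compounds isolates this change, so its size and direction can only be guessed. Compound 1 and compound 3 show that a hydroxy pyridine can reach low numbers here, but on different cores, which says nothing firm about compound 2's core.

Compound 4 is expected to land near compound 2, with a modest loss as the more likely direction, a step of a 3.8-fold higher number from compound 2 to compound 4 (0.57 log units; beyond the scatter). The estimate for compound 4 in this assay is 3 nM, within the range 0.6 nM to 15 nM.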

Compound 4, half-maximal inhibitory concentration: 29 nM
Beside the measured number, compound 4's estimate is 9.7-fold (0.99 log units) below it; the whole stated range lies below it.
By their numbers in this assay, from the lowest: compound 2; then compounds 1 and 4 (each within the scatter of the next); then compound 3.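

In this assay, for the compounds shown here, the change from methoxy to hydroxy on the shared core gives a 36-fold higher number from compound 2 to compound 4 (1.56 log units; beyond the scatter) and so provides the first direct reading of this change, with everything else in the structure held constant. The earlier hydroxy compounds stood on other cores and could not separate the group on the oxygen from the core, whereas this pair shows that replacing the methyl with hydrogen at this oxygen clearly weakens inhibition on this core. Nothing available explains the size of this step.

Going by these compounds, whether a step of this size carries over to the cores of compound 1 and compound 3 remains open. Also open, on these data alone, is how a longer chain on the oxygen, such as ethoxy, or an amine in place of the hydroxy group would read at this position.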